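Acetyl to benzofuranyl on the shared core: cytotoxicity notes

The source may report more compounds than this note shows. Statements on the series, on what has been measured and on what is new or still open speak of the compounds shown alone.

Compound 1 `CC(=O)c1ccc(NCc2cncn2Cc2ccc(-c3ccccc3)cc2)cc1-c1ccccc1` — > 10000 nM
Compound 2 `COC(=O)c1ccc(NCc2cncn2Cc2ccc(F)cc2)cc1-c1ccccc1` — "not determined" (no result reported)

In a toxicity assay on NIH3T3 cells (Mus musculus) for cytotoxicity, read by resazurin assay (a lower number here means that less compound is needed, a higher number that more compound is needed for the effect), compound 1 gives > 10000 nM, which is a limit of the assay rather than a number (the limit of > 10000 nM in this assay, at which 1 of the 2 values shown sits). For compound 2 this assay reports "not determined" (no result reported). Compound 3 `c1ccc(-c2ccc(Cn3cncc3CNc3ccc(-c4cc5ccccc5o4)c(-c4ccccc4)c3)cc2)cc1` is still to be measured in this assay; it differs from compound 1 by 1-benzofuran-2-yl in place of acetyl on an aromatic carbon. Within the data shown here, no step between measured compounds is available, so the size of the change is open; the step is expected to stay small, not clearly beyond the scatter, an at least 1.2-fold lower number from compound 1 to compound 3 (0.09 log units; that floor lies within the scatter). For compound 3 the expected value in this assay is 8000 nM, within a range from 2000 nM to 30000 nM.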

Compound 3, half-maximal effective concentration: > 10000 nM
Compound 3 ended at the assay's limit; the forecaster's own chance of this, stated with the estimate: 55%; at least 1.2-fold (0.09 log units) between middle value and limit.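

Compound 1 and compound 3 both stand at a limit in this assay, so no step from the acetyl to the 1-benzofuran-2-yl compound can be read: the limit of > 10000 nM in this assay, at which 2 of the 3 values shown sit.

The compounds shown leave open what concentration of either compound reaches the half-maximal effect in this assay.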